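A Tetrazolylamino Amide in Place of Methylpiperazine

This account rests on a few compounds, and the source may have more. Where it says the series, first, only, none or still open, it means among the compounds named here.

In a functional assay on cells (Mast cell, Rattus norvegicus) for inhibition, with a stated time of 15 min (on this read-out higher numbers stand for an effect only at larger amounts of compound and lower numbers for an effect already at smaller amounts), compound 1 (`CN1CCN(C(=O)/C=C/c2coc3ccccc3c2=O)CC1`) gives > 18 ug/mL as its result, which is a limit of the assay and not a number. Its true position is therefore unknown, and it offers no exact starting point.

Compound 3 (`O=C(/C=C/c1coc2ccccc2c1=O)Nc1nnn[nH]1`) keeps the core of compound 1. On the carbonyl carbon, (1H-tetrazol-5-yl)amino takes the place of 4-methylpiperazin-1-yl ((1H-tetrazol-5-yl)amino in place of 4-methylpiperazin-1-yl on a carbonyl carbon) and the double-bonded chain carbon stays in place.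

Within the data shown here, no measured pair of compounds differs in this one place alone. Among the measured compounds shown here, the only other guide is compound 2 (`O=C(Nc1nnn[nH]1)c1cc(=O)c2ccc(O)cc2o1`), which bears the same (1H-tetrazol-5-yl)amino on a carbonyl carbon but has a different core. Compound 2 gives 0.11 ug/mL in this assay and so shows an effect already at small amounts.

On the strength of that value, a large step towards smaller amounts is expected, well beyond the scatter. The expected size is an at least 45-fold lower number from compound 1 to compound 3 (1.65 log units; beyond the scatter) as an estimate that starts from a limit. In this assay the estimated value for compound 3 is 0.4 ug/mL with an expected range from 0.05 ug/mL to 3 ug/mL for repeated measurements.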

Compound 3, concentration for half-maximal effect: 6 ug/mL
Compound 3: middle estimate off by 15-fold (1.18 log units), on the low side; measured number above the stated range.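

Among these compounds, replacing 4-methylpiperazin-1-yl with (1H-tetrazol-5-yl)amino on a carbonyl carbon gives the first step that can be read at this position in this assay, and it is an at least 3.0-fold lower number from compound 1 to compound 3 (0.47 log units; beyond the scatter). This step is only a minimum, and its true size remains unknown, because the result for compound 1 is a limit of the assay and not a number: the limit of > 18 ug/mL in this assay, at which 1 of the 3 values shown sits.
Among the compounds shown here, on the shared core, compound 3 at 6 ug/mL nevertheless provides the first exact value for this position, so the change can now be tied to a real number on one side.

With a single replacement at this position, the compounds shown do not tell whether the whole (1H-tetrazol-5-yl)amino group is needed, or whether a phenylamino group, a simple amine or a carboxylic acid in the same place would give a similar result. Going by these compounds, compound 2, at 0.11 ug/mL, has a different core, and how much of that value comes from the core and how much from the (1H-tetrazol-5-yl)amino group also remains open.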